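The source may report more compounds than this note shows. Statements on the series, on what has been measured and on what is new or still open speak of the compounds shown alone.

The compounds measured so far:

Compound 1 `CCCCCCCCC(=O)N1c2ccccc2CCC1C(=O)Nc1ccccc1C(F)(F)F` gives 8330 nM in a functional assay on ACHN cells (Homo sapiens) for cytotoxicity, read by sulforhodamine B assay, with a stated time of 72 h; on this read-out lower numbers stand for stronger inhibition of growth and higher numbers for weaker inhibition of growth.
Compound 2 `CCCCCCCCC(=O)N1c2ccccc2CCC1C(=O)Nc1ccccc1O` gives 65000 nM in this assay.
Compound 3 `O=C(Nc1cc(C(F)(F)F)cc(C(F)(F)F)c1)C1CCc2ccccc2N1` gives 8190 nM in this assay.

Among these three numbers compound 1 stands second highest. Among the measured compounds shown here, compound 3 is nearest to it, within the scatter, and compound 2 is furthest, the one measured step being a 7.8-fold higher number from compound 1 to compound 2 (0.89 log units; beyond the scatter), a modest change that lies beyond the scatter.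

Compound 4 `CCC(=O)N1c2ccccc2CCC1C(=O)Nc1ccccc1C(F)(F)F` has not yet been measured. It differs from compound 1 by hydrogen in place of hexyl on a saturated chain carbon, two bonds along the chain from a carbonyl carbon. For the measured compounds named here, no measured step bears directly on this change: the single step, a 7.8-fold higher number from compound 1 to compound 2 (0.89 log units; beyond the scatter), concerns the group on the aromatic ring, not the acyl chain. Compound 3, which lacks the acyl chain altogether and carries a different aromatic substitution, gives a number within the scatter of compound 1, so the available numbers give no sign that shortening the chain would move the number far. Compound 4 is therefore expected to lie close to compound 1, with a 1.4-fold higher number from compound 1 to compound 4 (0.16 log units; within the scatter) not clearly beyond the scatter in either direction. The estimate for compound 4 in this assay is 12000 nM, with a range from 3000 nM to 45000 nM.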

Compound 4, concentration for 50% growth inhibition: > 80000 nM
Compound 4: only a limit was reported (the forecaster's own chance of this, stated with the estimate: 10%); at least 6.6-fold (0.82 log units) between middle value and limit.
By their numbers in this assay, from the lowest: compounds 3 and 1 (each within the scatter of the next); then compound 2. At a limit, above all of these: compound 4.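

In this assay, the acyl chain proves to be a position where a change moves the number: going from octylcarbonyl to propanoyl, with the rest of the structure kept, gives an at least 9.6-fold higher number from compound 1 to compound 4 (0.98 log units; beyond the scatter). This is the first step shown at this chain, and it shows that the shared core with its trifluoromethyl group does not hold the growth inhibition of compound 1 once the hexyl is replaced by hydrogen. The reading for compound 4 is a limit of the assay and not a number: the limit of > 80000 nM in this assay, at which 1 of the 4 values shown sits.

Going by these compounds, it remains open how the number runs between the two chain lengths, for instance with a butanoyl or hexanoyl chain, and whether a longer chain such as decanoyl or an amine at the chain end would change it. On these data alone, whether the same shortening would act alike with the hydroxy of compound 2 also stays open.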